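The source may report more compounds than this note shows. Statements on the series, on what has been measured and on what is new or still open speak of the compounds shown alone.

In an ADME assay on L1210/0 cells (Mus musculus) for cytotoxicity, with a stated time of 48 h (a lower number here means a stronger inhibitor, a higher number a weaker inhibitor), compound 2 (`CC1(C)[C@@H](CO)CC[C@@]1(C)Cn1ccc(=O)[nH]c1=O`) gives > 200000 nM, which is a limit of the assay and not a number. Compound 1 (`CC1(C)[C@@H](CO)CC[C@@]1(C)Cn1cc(I)c(=O)[nH]c1=O`) gives > 200000 nM, which is likewise only a limit. The whole record so far comes down to the limit of > 200000 nM in this assay, at which 2 of the 2 values shown sit, so compound 2 has no readable position of its own.

The next compound, compound 3 (`CC1(C)[C@@H](CO)CC[C@@]1(C)Cn1cc(Br)c(=O)[nH]c1=O`), differs from compound 2 by bromo in place of hydrogen on an aromatic carbon. Among the measured compounds shown here, the only measured step that bears on this change is a step that the two limits leave unreadable from compound 1 to compound 2, where hydrogen takes the place of iodo on an aromatic carbon. That step has no readable size, and it gives no direction. Neither the iodo compound nor the hydrogen compound yielded a number, so no step beyond the scatter is anticipated in this assay when bromo enters.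

The expected change is a number no higher from compound 2 to compound 3 (the limit leaves the size open), with no direction favoured. For compound 3 the estimated value is 200000 nM, with an expected range from 100000 nM to 400000 nM, and the assay will most likely report only a limit again.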

Compound 3, half-maximal inhibitory concentration: > 200000 nM
Compound 3: no number, only a limit; the forecaster's own chance of this, stated with the estimate: 85%; the middle value sits exactly at the limit.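

In this assay compound 3 gives > 200000 nM, which is again a limit of the assay and not a number. No new step can be read between compound 3 and either compound 1 or compound 2. The compounds shown leave open whether hydrogen, bromo or iodo on the aromatic carbon makes any difference in this assay, since the record comes down to one value: the limit of > 200000 nM in this assay, at which 3 of the 3 values shown sit.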